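Swapping Isobutyl for a Cyclobutyl Amide on the Ring Nitrogen

The source may hold more compounds than are shown below. What is called first, only, known or untested is meant among the compounds shown, and "the series" means these compounds.

Compound 1 `Cc1cccc(C#Cc2nc3c(s2)C(=O)NCC3)c1`: > 10000 nM
Compound 2 `CC(C)CN1CCc2nc(C#Cc3ccccc3)sc2C1`: > 10000 nM
Compound 3 `O=C(C1CC(F)(F)C1)N1CCc2nc(C#Cc3cccc(F)c3)sc2C1`: 2.5 nM

In an assay on HEK293 cells for positive allosteric modulation of metabotropic glutamate receptor 5 (Homo sapiens), read by FLIPR, with a stated time of 1 h (a lower number here means that less compound is needed, a higher number that more compound is needed for the effect), compound 2 gives only a limit, > 10000 nM, not a number. Compound 2 therefore sits at the limit of > 10000 nM in this assay, at which 2 of the 3 values shown sit, as does compound 1. Compound 3, which carries a carbonyl on the same ring nitrogen instead of a plain alkyl group, gives 2.5 nM in this assay. Compound 4 `COC1CC(C(=O)N2CCc3nc(C#Cc4ccccc4)sc3C2)C1` has not been measured yet. It differs from compound 2 by (3-methoxycyclobutyl)carbonyl in place of isobutyl on an amine nitrogen in a ring. Since compound 3 reaches a measured value of 2.5 nM with a carbonyl on that nitrogen, a gain well beyond the scatter is expected here. The step of an at least 660-fold lower number from compound 2 to compound 4 (2.82 log units; beyond the scatter) is expected to be large, toward less compound needed. Compound 4 is estimated at 15 nM, between 3 nM and 100 nM.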

Compound 4, half-maximal effective concentration: 640 nM
Compound 4: middle estimate off by 43-fold (1.63 log units), on the low side; the measured number lies above the stated range.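

On the ring nitrogen, (3-methoxycyclobutyl)carbonyl in place of isobutyl yields a real number: in this assay compound 4 gives 640 nM. For the compounds shown here, the change produces an at least 15-fold lower number from compound 2 to compound 4 (1.19 log units; beyond the scatter), the first step that can be read at this position. That step is only a minimum, since compound 2 has a limit and not a number: the limit of > 10000 nM in this assay, at which 2 of the 4 values shown sit.

Which part of the new group carries the gain stays open: the carbonyl, the four-membered ring or the methoxy. A plain acetyl on this nitrogen, or a hydroxyl in place of the methoxy, would help separate these parts.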